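This account rests on a few compounds, and the source may have more. Where it says the series, first, only, none or still open, it means among the compounds named here.

In an in vitro functional assay on cells (Fibroblast) for agonist activity at Alpha-1A adrenergic receptor (Homo sapiens) (a lower number here means that less compound is needed, a higher number that more compound is needed for the effect), the measured compounds are compound 1 `CCn1nccc1-c1ccccc1NCC1=NCCN1` with 63.1 nM, compound 2 `CCCn1nccc1-c1ccccc1NCC1=NCCN1` with 251 nM, and compound 3 `Cn1ccc(-c2ccccc2NCC2=NCCN2)n1` with 3.16 nM.

Compound 3 gives the lowest number of the three, well apart from both others. Compound 1 and compound 2 share one core and compound 3 has another; the difference between the two cores is not broken down here. Within the first core, the change methyl in place of hydrogen on a saturated chain carbon, two bonds along the chain from an aromatic nitrogen gave a 4.0-fold higher number from compound 1 to compound 2 (0.60 log units; beyond the scatter).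

Compound 4 `CCn1ccc(-c2ccccc2NCC2=NCCN2)n1` is not yet measured. It differs from compound 3 by methyl in place of hydrogen on a saturated chain carbon bound to an aromatic nitrogen. Going by the values given here, this is the same kind of change as the one from compound 1 to compound 2, but not the same: in compound 4 the methyl enters on a saturated chain carbon bound to an aromatic nitrogen, whereas in compound 2 it entered on a saturated chain carbon two bonds along the chain from an aromatic nitrogen. Among the compounds with values here, the only measured instance of lengthening this chain is the step from compound 1 to compound 2, so the expectation for compound 4 rests on that step alone. Compound 4 is expected to show a 2.5-fold higher number from compound 3 to compound 4 (0.40 log units; beyond the scatter), a loss of similar size, because the earlier step gave a 4.0-fold higher number from compound 1 to compound 2 (0.60 log units; beyond the scatter). In this assay compound 4 is therefore estimated at 8 nM.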

Compound 4, half-maximal effective concentration: 25.1 nM
Compound 4: middle estimate off by 3.1-fold (0.50 log units), on the low side; the measured number lies above the stated range.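

In this assay, the new step is a 7.9-fold higher number from compound 3 to compound 4 (0.90 log units; beyond the scatter), so methyl in place of hydrogen on the chain raises the number on the core of compound 3, in the same direction as on the core of compound 1. The two steps cannot be told apart in size: the same change on two cores in this assay, a 4.0-fold higher number (0.60 log units; beyond the scatter) from compound 1 to compound 2 and a 7.9-fold higher number (0.90 log units; beyond the scatter) from compound 3 to compound 4, 2.0-fold (0.30 log units) apart, within the scatter of two such steps. This shows that the direction of the change carried over between these two cores, but it rests on a single pair of steps, with the methyl entering at a different place on the chain in each, so it does not show that the change would behave alike on any further core.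

The compounds shown leave open whether the number keeps rising on the core of compound 3 with a longer chain, or how a branched chain such as isopropyl or a chain ending in a hydroxyl group would compare. They also leave open how the two cores themselves differ, apart from these chain changes.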